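A larger aromatic group in place of isopropyl

The compounds below may be only part of what the source reports. "The series", "measured", "known", "first", "only" and "open" are said of these compounds alone.

Three amides sharing one core have been tested in a functional assay on MDA-MB-231 cells (Homo sapiens) for antiproliferative activity, read by MTT assay, with a stated time of 72 h; on this read-out higher numbers stand for weaker inhibition and lower numbers for stronger inhibition. Compound 1, `O=C(CCc1cccc2c1B(O)OC2)NC1CCCCC1`, carries a cyclohexyl group on the amide nitrogen; in this assay compound 1 reaches only the limit of > 100000 nM, which is the edge of what the assay reports rather than a measured number, as recorded in the limit of > 100000 nM in this assay, at which 1 of the 3 values shown sits. Compound 2, `CC(C)(C)OC(=O)Nc1ccc(NC(=O)CCc2cccc3c2B(O)OC3)cc1`, places an aromatic ring on the amide nitrogen bearing a carbamate, and in this assay compound 2 gives 29000 nM. For the measured compounds named here, compound 3, `CC(C)c1cccc(NC(=O)CCc2cccc3c2B(O)OC3)c1`, has instead an isopropyl group on that ring, and in this assay compound 3 gives 1600 nM, the lowest number among the values so far, and its distance from compound 2 lies beyond the usual scatter.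

Compound 4, `O=C(CCc1cccc2c1B(O)OC2)Nc1cccc(-c2cccc(C(F)(F)F)c2)c1`, has not yet been measured. It differs from compound 3 at a single point: 3-(trifluoromethyl)phenyl in place of isopropyl on an aromatic carbon. Going by the values given here, no measured pair tells what such a change does, so the step can only be guessed from the trend that the two aromatic amides already show. For compound 4 the expected step is a 2.0-fold lower number from compound 3 to compound 4 (0.30 log units; within the scatter), a modest gain in inhibition that may still fall within the scatter. Compound 4 is therefore estimated to give 800 nM, within a range from 200 nM to 4000 nM.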

Compound 4, half-maximal inhibitory concentration: 410 nM
Beside the measured number, compound 4's estimate is 2.0-fold (0.29 log units) above it, within the range that was stated.
By their numbers in this assay, from the lowest: compound 4; then compound 3; then compound 2. At a limit, above all of these: compound 1.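

In this assay, for the compounds shown here, the exchange of isopropyl for 3-(trifluoromethyl)phenyl brings a 3.9-fold lower number from compound 3 to compound 4 (0.59 log units; beyond the scatter) and so gives the first reading of a change made at a single place. The step lies beyond the usual scatter, and it shows that this aromatic carbon tolerates much more than the isopropyl group: 10 heavy atoms and a whole six-membered aromatic ring of carbon only stand where 3 heavy atoms stood, and inhibition grows rather than being lost. Nothing measured here explains this gain, and the one available note on the series, the limit reached by compound 1, does not bear on it.

The compounds shown leave open whether the gain belongs to the added ring itself or to the trifluoromethyl group it carries, a question that a plain phenyl group on the same carbon would separate. Also open, from the compounds shown here alone, is how this assay would respond if that outer ring carried an amine or a carboxylic acid in place of the trifluoromethyl group.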